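Sulfonyl in place of indolecarbonyl on the octadecyl amide

The source may report more compounds than this note shows. Statements on the series, on what has been measured and on what is new or still open speak of the compounds shown alone.

The series is followed in a functional assay on HepG2 cells (Homo sapiens) for cytotoxicity, read by MTT assay, with a stated time of 48 h; a higher number here means a weaker inhibitor, a lower number a stronger inhibitor. Compound 1 `CCCCCCCCCCCCCCNC(=O)[C@@H](NS(=O)(=O)c1ccc(C)cc1)[C@@H](C)O` gives 10900 nM. Compound 2 `CCCCCCCCCCCCCCCCCCNC(=O)[C@@H](NC(=O)c1cc2ccccc2n1C)[C@@H](C)O` carries the longer chain and the indolecarbonyl group; for compound 2 this assay gives only a limit, > 200000 nM, so compound 2 stands at the edge of what the assay reports, as noted in the limit of > 200000 nM in this assay, at which 1 of the 2 values shown sits. Compound 3 `CCCCCCCCCCCCCCCCCCNC(=O)[C@@H](NS(=O)(=O)c1ccc(C)cc1)[C@@H](C)O` is the next step: (4-methylphenyl)sulfonyl in place of (1-methyl-1H-indol-2-yl)carbonyl on an amine nitrogen. For the measured compounds named here, no measured step between compounds that differ only at this amide is available, so the expectation rests on the fact that the same sulfonyl group sits on compound 1, which gives a number rather than a limit. The step from compound 2 to compound 3 is therefore expected to run toward stronger inhibition, by an at least 10-fold lower number from compound 2 to compound 3 (1.00 log units; beyond the scatter), well beyond the scatter. Compound 3 is estimated at 20000 nM, with a range of 6000 nM to 90000 nM.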

Compound 3, half-maximal inhibitory concentration: 75800 nM
For compound 3 the middle estimate is 3.8-fold (0.58 log units) below the measured one; measured number inside the range.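

In this assay, (4-methylphenyl)sulfonyl in place of (1-methyl-1H-indol-2-yl)carbonyl on an amine nitrogen, with the chain unchanged, gives an at least 2.6-fold lower number from compound 2 to compound 3 (0.42 log units; beyond the scatter), so a change at this nitrogen alone moves the read-out beyond the scatter. The true size of that step stays unknown, because compound 2 carries a limit and not a number: the limit of > 200000 nM in this assay, at which 1 of the 3 values shown sits.

With the sulfonyl group held fixed, butyl in place of hydrogen on the chain gives a 7.0-fold higher number from compound 1 to compound 3 (0.84 log units; beyond the scatter), so the longer chain goes with weaker inhibition in this pair. As far as these compounds go, whether a dodecyl chain or a chain longer than octadecyl would continue this direction remains open. Also open, from the compounds shown here alone, are how the (1-methyl-1H-indol-2-yl)carbonyl group reads on the shorter chain of compound 1, and whether a methanesulfonyl group on the amine nitrogen would match the (4-methylphenyl)sulfonyl group.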